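The source may hold more compounds than are shown below. What is called first, only, known or untested is meant among the compounds shown, and "the series" means these compounds.

Measured compounds:
- compound 2, `CC(=O)NC1CCN(c2ncnc3[nH]cc(-c4cccc(Cl)c4)c23)CC1`: 122 nM
- compound 1, `OCCCNc1ncnc2[nH]cc(-c3cccc(Cl)c3)c12`: 552 nM

Of the compounds shown here, two share the same core and have been measured in an assay on HEK293T cells for displacement of a labelled ligand from serine/threonine-protein kinase 4 (Homo sapiens), read by NanoBRET, with a stated time of 2 h; on this read-out lower numbers stand for stronger inhibition and higher numbers for weaker inhibition. Compound 2 gives 122 nM, the lower of the two numbers and therefore the stronger binder of the pair. Compound 1 gives 552 nM, a gap from compound 2 that lies beyond the usual scatter. The two compounds differ in more than one place, so nothing can be said about which part of that difference matters.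

Compound 3, `OC1CCN(c2ncnc3[nH]cc(-c4cccc(Cl)c4)c23)CC1`, keeps the six-membered ring of compound 2 and changes only the group on it: hydroxy in place of acetamido on a saturated ring carbon. The acetamido group is replaced by a far smaller hydroxy group that keeps a hydrogen-bond donor and acceptor. With no comparable single change measured, the direction is uncertain; a modest loss is expected, since compound 2 already stands at the better end at 122 nM. The step from compound 2 to compound 3 is estimated as a 2.0-fold higher number from compound 2 to compound 3 (0.31 log units; beyond the scatter). Compound 3 is expected to give about 250 nM, within a range from 80 nM to 800 nM.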

Compound 3, half-maximal inhibitory concentration: 250 nM
Compound 3: the middle estimate sits on the measured number at the digits printed; low and high end bracket the measured number.
By their numbers in this assay, from the lowest: compound 2; then compound 3; then compound 1.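

Shortening the acetamido group to a hydroxy group on this saturated ring carbon gives a 2.0-fold higher number from compound 2 to compound 3 (0.31 log units; beyond the scatter), so the step is real but modest, and binding survives the loss of most of the group's heavy atoms. The groups that leave and enter have the same count of hydrogen-bond donors and acceptors, which means this pair changes the size of the group without changing those counts. Placing 4-hydroxypiperidin-1-yl in place of (3-hydroxypropyl)amino on the aromatic carbon gives a 2.2-fold lower number from compound 1 to compound 3 (0.34 log units; beyond the scatter), the first reading of a ring against an open chain, with a hydroxy group present on both sides, although nothing available explains either step.

The compounds shown leave open what an amine or a carboxylic acid would do on the same saturated ring carbon, and whether a longer chain there would move the number further in either direction. They also leave open which part of the acetamido group accounts for its lower number, the carbonyl or the amide hydrogen, or simply its larger size, and a methoxy group or a plain amide at that carbon would be needed to separate these.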